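The source may hold more compounds than are shown below. What is called first, only, known or untested is meant among the compounds shown, and "the series" means these compounds.

Measured so far:
compound 1, `Cc1cc(-n2ccnc2)c2ncc(CSCCc3ccccc3)n2c1`: 10 ug/mL
compound 2, `Cc1cc(-n2ccc3cccnc32)c2ncc(CSCCc3ccccc3)n2c1`: > 100 ug/mL

In an ADME assay on HEL cells (Homo sapiens) for cytotoxicity, with a stated time of 3 days (a lower number here means that less compound is tolerated, a higher number that more compound is tolerated), compound 1 gives 10 ug/mL. For compound 2 the reported > 100 ug/mL is a limit of the assay and not a number, as marked by the limit of > 100 ug/mL in this assay, at which 1 of the 2 values shown sits. Among the measured compounds shown here, the single measured step is an at least 10-fold higher number from compound 1 to compound 2 (1.00 log units; beyond the scatter), so compound 2 stands at the top of the range this assay reports.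

Compound 3, `Cc1cc(Sc2ccc(O)cc2)c2ncc(CSCCc3ccccc3)n2c1`, differs from compound 2 by a group of 8 heavy atoms (6 carbon, 1 oxygen, 1 sulfur; one six-membered aromatic ring of carbon only) in place of a group of 9 heavy atoms (7 carbon, 2 nitrogen; one five-membered aromatic ring with 1 hetero atom, one six-membered aromatic ring with 1 hetero atom), on an aromatic carbon. For the measured compounds named here, no measured step concerns this particular exchange; the known step of an at least 10-fold higher number from compound 1 to compound 2 (1.00 log units; beyond the scatter) replaces one group on the same aromatic carbon with another and shows only that a change at this position can move the read-out beyond the scatter. With compound 2 at a limit, a number the same or lower is expected for compound 3. The estimate for compound 3 is 50 ug/mL, range 12 ug/mL to 150 ug/mL. This expected estimate corresponds to an at least 2.0-fold lower number from compound 2 to compound 3 (0.30 log units; that floor lies within the scatter).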

Compound 3, half-maximal cytotoxic concentration: 79 ug/mL
Estimate against measurement, compound 3: 1.6-fold (0.20 log units) below; low and high end bracket the measured number.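

At this aromatic carbon, a second exchange away from 1H-imidazol-1-yl moves the read-out in this assay beyond the scatter, with (4-hydroxyphenyl)sulfanyl giving a 7.9-fold higher number from compound 1 to compound 3 (0.90 log units; beyond the scatter). The higher number is therefore not tied to the two-ring group of compound 2, and against that group the step is only an at least 1.2-fold lower number from compound 2 to compound 3 (0.10 log units; that floor lies within the scatter), which does not separate the two entering groups. Compound 2 stands at a limit of the assay and not at a number: the limit of > 100 ug/mL in this assay, at which 1 of the 3 values shown sits.

On these data alone, how far compound 2 really lies from compound 3 stays open, as does the part that the hydroxyl and the sulfur link each play in the result. A plain phenylsulfanyl group and a phenoxy group at this carbon would bear on those two parts.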